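A change of two stereo elements in compound 1

This account rests on a few compounds, and the source may have more. Where it says the series, first, only, none or still open, it means among the compounds named here.

Measured so far:
- compound 1 `Nc1ncnc2c1ncn2/C=C1/C[C@H]1[C@H](O)CO`: 206000 nM
- compound 2 `Nc1nc2c(ncn2/C=C2/CC2(CO)CO)c(=O)[nH]1`: > 100000 nM (a limit of the assay)
- compound 3 `Nc1ncnc2c1ncn2/C=C1/C[C@@H]1[C@H](O)CO`: > 300000 nM (a limit of the assay)

For the measured compounds named here, in an ADME assay on HFF cells (Homo sapiens) for cytotoxicity, read by neutral red uptake (on this read-out lower numbers stand for higher toxicity in this test and higher numbers for lower toxicity in this test), compound 1 gives 206000 nM as the only actual number. The other two results are limits of the assay. Compound 4 `Nc1ncnc2c1ncn2/C=C1\C[C@H]1[C@@H](O)CO` has not yet been measured, and its relation to compound 1 is this: the two compounds have the same atoms and bonds and differ only in configuration as drawn: 2 of 3 stereo elements differ; a stereocentre at a saturated chain carbon is drawn S in compound 1 and R in compound 4; a double bond is drawn Z in compound 1 and E in compound 4. Going by the values given here, only one measured step offers any guide: an at least 1.4-fold higher number from compound 1 to compound 3 (0.16 log units; that floor lies within the scatter). That step concerns a stereocentre at a saturated ring carbon, so neither the saturated chain carbon nor the double bond altered in compound 4 has been tested on its own. Among the compounds with values here, with compound 3 as the sole comparison, and its step from compound 1 not beyond the scatter, no clear change is expected here. The expected step is a 1.2-fold higher number from compound 1 to compound 4 (0.07 log units; within the scatter) in this assay, within the scatter and with no firm direction. For compound 4 the estimated value is 240000 nM, with an expected range from 110000 nM to 450000 nM in this test.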

Compound 4, half-maximal cytotoxic concentration: 264000 nM
Beside the measured number, compound 4's estimate is 1.1-fold (0.04 log units) below it; the measured number falls inside the stated range.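

In this assay, inverting the saturated chain carbon from S to R and switching the double bond from Z to E together give a 1.3-fold higher number from compound 1 to compound 4 (0.11 log units; within the scatter), a joint change that the earlier compounds did not cover, and nothing else differs: the fact that compounds 1 and 4 differ only in the configuration as drawn

Compound 3 stands at a limit of the assay, > 300000 nM. Changing all three stereo elements at once gives an at least 1.1-fold lower number from compound 3 to compound 4 (0.05 log units; that floor lies within the scatter), so this pair shows no change beyond the scatter either, though the limit leaves its true size unknown.

The compounds shown leave open how the saturated chain carbon and the double bond each act alone, as the two change together in compound 4. They also leave open how this read-out would respond to an amine or a carboxylic acid on the side chain in place of a hydroxyl group.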